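The compounds below may be only part of what the source reports. "The series", "measured", "known", "first", "only" and "open" are said of these compounds alone.

Measured compounds:
- compound 1, `CN(c1cccc2c1CN(c1nc(Nc3ccc(C(F)(F)F)cc3)ncc1C(F)(F)F)C2)S(C)(=O)=O`, > 30000 nM in a functional assay on HepG2 cells (Homo sapiens) for antiproliferative activity, read by spectrophotometry, with a stated time of 2 days; on this read-out lower numbers stand for stronger inhibition of growth and higher numbers for weaker inhibition of growth
- compound 2, `CN(c1cccc2c1CN(c1nc(Nc3cccc(Oc4ccccc4)c3)ncc1C(F)(F)F)C2)S(C)(=O)=O`, 23000 nM in this assay

Both measured compounds share a core and differ only in the substituted phenyl carried on the amino group. In this assay compound 1 gives > 30000 nM, which is a limit of the assay rather than a number. This places compound 1 at the weak end of what the assay can report, as shown by the limit of > 30000 nM in this assay, at which 1 of the 2 values shown sits. In this assay compound 2 gives 23000 nM, a number close to the same region, so the two values show only weak inhibition of growth for both.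

Compound 3, `CN(c1cccc2c1CN(c1nc(Nc3cc(Cl)cc(C(F)(F)F)c3)ncc1C(F)(F)F)C2)S(C)(=O)=O`, has not yet been measured. It differs from compound 1 by a single change: 3-chloro-5-(trifluoromethyl)phenyl in place of 4-(trifluoromethyl)phenyl on a nitrogen on an aromatic ring. For the measured compounds named here, no measured pair shows what this kind of change does, so no direction can be read from the data. The step of a number no higher from compound 1 to compound 3 (the limit leaves the size open) is expected to stay within the usual scatter, with a fair chance that the assay again reports only a limit. Compound 3 is therefore estimated at 30000 nM, with a range from 8000 nM to 100000 nM.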

Compound 3, concentration for 50% growth inhibition: 9900 nM
Compound 3: middle estimate off by 3.0-fold (0.48 log units), on the high side; the range from low to high includes it.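

For the compounds shown here, this is the first measured step at this position: 3-chloro-5-(trifluoromethyl)phenyl in place of 4-(trifluoromethyl)phenyl on a nitrogen on an aromatic ring gives an at least 3.0-fold lower number from compound 1 to compound 3 (0.48 log units; beyond the scatter) in this assay. Going by these compounds alone, the substituted phenyl on the amino group can therefore move this read-out beyond the usual scatter while the shared core stays the same, something no earlier pair could show. The true size of the step cannot be stated because compound 1 is reported only as a limit of the assay, so the step gives a lowest size and no upper end: the limit of > 30000 nM in this assay, at which 1 of the 3 values shown sits.

The change adds a chlorine and also alters where the trifluoromethyl stands on the ring, and the compounds shown do not separate these two parts, so it remains unknown which of them accounts for the step. Also open, as far as these compounds go, is whether a different group on this phenyl, such as an amine or a carboxylic acid, would lower the number further or raise it again.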